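This account rests on a few compounds, and the source may have more. Where it says the series, first, only, none or still open, it means among the compounds named here.

Compound 1 `COc1ccccc1N1C(=O)CSC1c1cc(F)cc(C(=O)NCCCCc2ccccc2)c1` gives 1430 mL.min-1.g-1 in an ADME assay on microsomes from liver (Mus musculus) for metabolic stability, read by LC-MS, using NADPH, with a stated time of 10 min, tested at 0.1 uM; on this read-out lower numbers stand for slow clearance and higher numbers for fast clearance.
Compound 2 `O=C(NCCCCc1ccccc1)c1cccc(C2SCC(=O)N2c2cccc(-c3c[nH]nn3)c2)c1` gives 951 mL.min-1.g-1 in this assay.

Both compounds are cleared quickly in this assay. The two numbers lie within the usual scatter of each other, so compound 2 stands alongside compound 1 rather than apart from it; no ordering between the two can be claimed.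

Compound 3 `O=C(NCCCCc1ccccc1)c1cccc(C2SCC(=O)N2c2ccc(C3CC3)cc2)c1` differs from compound 2 by a group of 9 heavy atoms (9 carbon; one three-membered non-aromatic ring of carbon only, one six-membered aromatic ring of carbon only) in place of a group of 11 heavy atoms (8 carbon, 3 nitrogen; one five-membered aromatic ring with 3 hetero atoms, one six-membered aromatic ring of carbon only), on an amide-type nitrogen in a ring. For the measured compounds named here, no pair of measured compounds shares a change of this kind, so the measured pair offers no direction for the step. What it does show is that two quite different groups on the amide-type nitrogen in a ring, in compound 1 and compound 2, give numbers that sit together. On that basis the step from compound 2 to compound 3 is expected to remain within the scatter, a 1.3-fold higher number from compound 2 to compound 3 (0.10 log units; within the scatter). Compound 3 is estimated at 1200 mL.min-1.g-1, between 550 mL.min-1.g-1 and 2600 mL.min-1.g-1.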

Compound 3, intrinsic clearance in microsomes: 2960 mL.min-1.g-1
For compound 3 the middle estimate is 2.5-fold (0.39 log units) below the measured one; measured number outside the range, above it.
By their numbers in this assay, from the lowest: compounds 2 and 1 (each within the scatter of the next); then compound 3.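

Changing the group on the amide-type nitrogen in the ring does move the number in this assay, with a 3.1-fold higher number from compound 2 to compound 3 (0.49 log units; beyond the scatter). Compounds 1 and 2 had left this open, as their values sit within the scatter of each other and they differ in more than one place. In this step, 4-cyclopropylphenyl, with no hydrogen-bond donors or acceptors, replaces a group carrying a five-membered aromatic ring with three nitrogens, and nothing available explains the higher number.

This single step cannot separate the loss of the five-membered aromatic ring from the arrival of the cyclopropyl ring. It also leaves open whether a carboxylic acid or an amine on the phenyl ring, in place of the cyclopropyl, would give a number nearer that of compound 2 or of compound 3.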